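This account rests on a few compounds, and the source may have more. Where it says the series, first, only, none or still open, it means among the compounds named here.

Three compounds share one core and differ only in the group attached to the amide-type nitrogen. Compound 1, `C=CC1=C(C(=O)Nc2ccccc2OC)C(c2ccc(F)cc2)OC1`, carries a 2-methoxyphenyl there and in a functional assay on QGY7701 cells (Homo sapiens) for cytotoxicity, read by MTT assay, with a stated time of 24 h (a higher number here means a weaker inhibitor, a lower number a stronger inhibitor), compound 1 gives 52800 nM. Compound 2, `C=CC1=C(C(=O)Nc2ccc(C)cc2)C(c2ccc(F)cc2)OC1`, carries a 4-methylphenyl, and in this assay compound 2 gives 59200 nM; the step of a 1.1-fold higher number from compound 1 to compound 2 (0.05 log units; within the scatter) lies within the scatter. Compound 3, `C=CC1=C(C(=O)NCCCCC)C(c2ccc(F)cc2)OC1`, carries a pentyl chain. In this assay compound 3 gives only a limit, > 100000 nM, so its true value is not known as a number; it sits at the limit of > 100000 nM in this assay, at which 1 of the 3 values shown sits. The steps toward it, an at least 1.8-fold higher number from compound 1 to compound 3 (0.27 log units; that floor lies within the scatter) and an at least 1.6-fold higher number from compound 2 to compound 3 (0.22 log units; that floor lies within the scatter), have floors that also lie within the scatter.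

Compound 4, `C=CC1=C(C(=O)NC2CCCCC2)C(c2ccc(F)cc2)OC1`, is not yet measured. It differs from compound 3 in one place: cyclohexyl in place of pentyl on an amide-type nitrogen. The measured steps bearing on this change are those into compound 3, which show at most a modest weakening on moving from an aryl group to a pentyl chain; none of them compares two non-aromatic groups. With compound 3 already at the limit, compound 4 is expected to stay near it, with the step that the limit leaves unreadable from compound 3 to compound 4 estimated as small. Compound 4 is therefore estimated at 120000 nM, within 45000 nM to 320000 nM.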

Compound 4, half-maximal inhibitory concentration: 40500 nM
Beside the measured number, compound 4's estimate is 3.0-fold (0.47 log units) above it; the whole stated range lies above it.
By their numbers in this assay, from the lowest: compounds 4, 1 and 2 (each within the scatter of the next). At a limit, above all of these: compound 3.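

In this assay, this position on the amide-type nitrogen separates two non-aromatic groups, with cyclohexyl in place of pentyl giving an at least 2.4-fold lower number from compound 3 to compound 4 (0.39 log units; beyond the scatter). Compound 3 stands at a limit and not at a number, so only the floor of that step is known: the limit of > 100000 nM in this assay, at which 1 of the 4 values shown sits. Compared with the two aryl compounds, the cyclohexyl group gives a 1.5-fold lower number from compound 2 to compound 4 (0.16 log units; within the scatter) and a 1.3-fold lower number from compound 1 to compound 4 (0.12 log units; within the scatter), so among these four compounds an aromatic ring on this nitrogen is not needed to reach the level of compounds 1 and 2, while compound 3, which also lacks an aromatic ring, goes against any simple rule that non-aromatic groups all read alike.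

The compounds shown leave open whether the ring itself or the carbon count matters here, a question that a hexyl chain, with the same number of carbons as cyclohexyl, and a cyclopentyl group could help to settle. They also leave open how this position would respond to a cyclohexyl ring bearing an amine or a carboxylic acid.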